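The source may report more compounds than this note shows. Statements on the series, on what has been measured and on what is new or still open speak of the compounds shown alone.

Of the compounds shown here, three built on one shared core have been measured in a functional assay on HeLa cells (Homo sapiens) for cytotoxicity, read by WST assay, with a stated time of 48 h; on this read-out higher numbers stand for weaker inhibition and lower numbers for stronger inhibition. Compound 1 `CCCCC[C@H](C(C)C)C(c1ccc(O)c(OC)c1)c1ccc(O)c(OC)c1` gives 9200 nM. Compound 2 `COc1cc(C(c2ccc(O)c(OC)c2)[C@H](C)[C@H](C)CF)ccc1O` gives 75000 nM. Compound 3 `COc1cc(C(c2ccc(O)c(OC)c2)[C@H](C)C(C)C)ccc1O` gives 16000 nM, which is the second highest of the three numbers: it sits within the scatter of compound 1 and well apart from compound 2.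

Going by the values given here, two measured steps touch the chain that carries the change. Trimming the chain, with hydrogen in place of butyl, gave a 1.7-fold higher number from compound 1 to compound 3 (0.24 log units; within the scatter). Removing a fluoro from the chain end gave a 4.7-fold lower number from compound 2 to compound 3 (0.67 log units; beyond the scatter), so the fluoro-bearing compound 2 was the weakest of the three; the full swap of chains reads an 8.2-fold higher number from compound 1 to compound 2 (0.91 log units; beyond the scatter).

Compound 4 `COc1cc(C(c2ccc(O)c(OC)c2)[C@H](CO)C(C)C)ccc1O` differs from compound 3 by hydroxy in place of hydrogen on a saturated chain carbon, three bonds along the chain from two aromatic carbons. Among the compounds with values here, no measured step adds a hydroxy, but the step from compound 2 to compound 3 shows that placing a small polar-looking heteroatom group on this chain went with a higher number, so a modestly higher number is expected here. Compound 4 is expected to give 40000 nM, within 12000 nM to 130000 nM. That expected step is a 2.5-fold higher number from compound 3 to compound 4 (0.40 log units; beyond the scatter).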

Compound 4, half-maximal inhibitory concentration: > 100000 nM
Compound 4: no number, only a limit; the forecaster's own chance of this, stated with the estimate: 10%; middle value at least 2.5-fold (0.39 log units) away from the limit.
By their numbers in this assay, from the lowest: compounds 1 and 3 (each within the scatter of the next); then compound 2. At a limit, above all of these: compound 4.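

In this assay compound 4 gives no number, only a limit of the assay: the limit of > 100000 nM in this assay, at which 1 of the 4 values shown sits. On this chain carbon, three bonds along the chain from two aromatic carbons, hydroxy in place of hydrogen gives an at least 6.2-fold higher number from compound 3 to compound 4 (0.79 log units; beyond the scatter), and hydroxy in place of butyl gives an at least 10-fold higher number from compound 1 to compound 4 (1.03 log units; beyond the scatter), so a position where trimming the chain stayed within the scatter does respond to a single hydroxy. Set against the fluoro-bearing chain, the change reads an at least 1.3-fold higher number from compound 2 to compound 4 (0.12 log units; that floor lies within the scatter), and that floor does not separate the two chains.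

From the compounds shown here alone, with only a limit for compound 4, the full size of the hydroxy step stays unknown. Going by these compounds, whether an aminomethyl group, a methoxymethyl group or a carboxylic acid at this carbon would read the same way also stays open.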